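The source may hold more compounds than are shown below. What is called first, only, known or untested is meant among the compounds shown, and "the series" means these compounds.

Measured compounds:
Compound 1 `CN(C(=O)NC(=O)c1ccccc1F)c1nc(C(F)(F)F)c(C(=O)N/N=C/c2ccc(C(F)(F)F)cc2)s1`: 3.87 ug/mL
Compound 2 `CN(C(=O)NC(=O)c1ccc(Cl)cc1Cl)c1nc(C(F)(F)F)c(C(=O)N/N=C/c2ccc(C(F)(F)F)cc2)s1`: 3.08 ug/mL
Compound 3 `CN(C(=O)NC(=O)c1ccc(F)c(F)c1)c1nc(C(F)(F)F)c(C(=O)N/N=C/c2ccc(C(F)(F)F)cc2)s1`: 3.85 ug/mL

These numbers come from a functional assay on BCG823 cells (Homo sapiens) for inhibition, read by MTT assay, with a stated time of 72 h; on this read-out higher numbers stand for weaker inhibition and lower numbers for stronger inhibition. Compound 3 stands second highest of the three, yet every gap among them lies within the usual scatter, so no order can be read from them. Compound 4 `CN(C(=O)NC(=O)c1ccc(C(F)(F)F)cc1)c1nc(C(F)(F)F)c(C(=O)N/N=C/c2ccc(C(F)(F)F)cc2)s1` differs from compound 3 in one place: 4-(trifluoromethyl)phenyl in place of 3,4-difluorophenyl on a carbonyl carbon. Within the data shown here, the steps that bear on this change all exchange the group on that same carbonyl carbon: a 1.3-fold lower number from compound 1 to compound 2 (0.10 log units; within the scatter), a 1.0-fold lower number from compound 1 to compound 3 (0.00 log units; within the scatter) and a 1.3-fold higher number from compound 2 to compound 3 (0.10 log units; within the scatter), none of them beyond the scatter. The expectation for this assay is therefore no step beyond the scatter, and a 1.1-fold lower number from compound 3 to compound 4 (0.03 log units; within the scatter) is the estimated step. Compound 4 is estimated at 3.6 ug/mL, with a range from 1.8 ug/mL to 7.5 ug/mL.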

Compound 4, half-maximal inhibitory concentration: > 100 ug/mL
Compound 4 ended at the assay's limit (the forecaster's own chance of this, stated with the estimate: 5%); middle value at least 27-fold (1.44 log units) from the limit.
By their numbers in this assay, from the lowest: compounds 2, 3 and 1 (each within the scatter of the next). At a limit, above all of these: compound 4.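

Placing 4-(trifluoromethyl)phenyl on the carbonyl carbon gives a step far larger than any seen among the earlier groups: an at least 25-fold higher number from compound 3 to compound 4 (1.41 log units; beyond the scatter), an at least 32-fold higher number from compound 2 to compound 4 (1.51 log units; beyond the scatter) and an at least 25-fold higher number from compound 1 to compound 4 (1.41 log units; beyond the scatter), each meaning weaker inhibition. The value of compound 4 is a limit, not a number: the limit of > 100 ug/mL in this assay, at which 1 of the 4 values shown sits. Compounds 1, 2 and 3 alone suggested that this place tolerated change, and compound 4 shows that one exchange there can cost much of the inhibition.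

On these data alone, it remains open whether the trifluoromethyl group alone carries this loss, and how a plain phenyl or a methoxyphenyl group on that carbonyl carbon would read.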